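The source may hold more compounds than are shown below. What is called first, only, known or untested is meant among the compounds shown, and "the series" means these compounds.

In a functional assay on KB cells (nasopharynx, Homo sapiens) for antiproliferative activity (a higher number here means a weaker inhibitor, a lower number a stronger inhibitor), compound 3 `N#Cc1c[nH]c2c(NS(=O)(=O)c3ccc(C(=O)O)cc3)cccc12` reads > 100 ug/mL, which is a limit of the assay and not a number. The change to compound 4 `N#Cc1c[nH]c2c(NS(=O)(=O)c3ccc(N)cc3)cccc12` is amino in place of carboxy on an aromatic carbon. Amino already stands in compound 1 `Nc1ccc(S(=O)(=O)Nc2cccc3cc[nH]c23)cc1`, at 36 ug/mL. Compound 2 `N#Cc1ccc(S(=O)(=O)Nc2cccc3c(C#N)c[nH]c23)cc1` gives 33 ug/mL, within the scatter of the value for compound 1. Among the compounds with values here, the one measured step at this place put carboxy in place of cyano: an at least 3.0-fold higher number from compound 2 to compound 3 (0.48 log units; beyond the scatter), beyond the scatter. Losing carboxy is therefore expected to lower the number in this assay by a similar or larger amount, an expected at least 4.5-fold lower number from compound 3 to compound 4 (0.65 log units; beyond the scatter). The estimate for compound 4 is 22 ug/mL, with an expected range of 4 ug/mL to 65 ug/mL.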

Compound 4, half-maximal inhibitory concentration: 4.4 ug/mL
For compound 4 the middle estimate is 5.0-fold (0.70 log units) above the measured one; low and high end bracket the measured number.
By their numbers in this assay, from the lowest: compound 4; then compounds 2 and 1 (each within the scatter of the next). At a limit, above all of these: compound 3.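

In this assay, amino on the aromatic carbon para to a large group outperforms both other groups tested there: an at least 22-fold lower number from compound 3 to compound 4 (1.35 log units; beyond the scatter), and a 7.5-fold lower number from compound 2 to compound 4 (0.88 log units; beyond the scatter). With amino held constant, cyano in place of hydrogen on an aromatic carbon also gives a gain beyond the scatter: an 8.2-fold lower number from compound 1 to compound 4 (0.91 log units; beyond the scatter). The step from carboxy is only a bound, as compound 3 is a limit of the assay: the limit of > 100 ug/mL in this assay, at which 1 of the 4 values shown sits.

Going by these compounds, whether a methylamino or hydroxyl group at the amino position would match amino remains open. So does whether a carboxamide in place of cyano would keep the gain.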